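This account rests on a few compounds, and the source may have more. Where it says the series, first, only, none or still open, it means among the compounds named here.

Three related compounds have been tested in a functional assay on SK-MEL-5 cells (Homo sapiens) for cytotoxicity, read by sulforhodamine B assay, with a stated time of 48 h, tested at 10 uM; on this read-out higher numbers stand for a weaker effect at the one concentration tested and lower numbers for a stronger effect. Compound 1 `COc1ccc(-c2cc(/C=C/C(=O)c3ccc(N)cc3)[nH]n2)cc1` gives -3% in this assay, and compound 2 `COc1ccc(-c2cc(/C=C/C(=O)c3ccc(N)cc3)[nH]n2)cc1OC` gives 6%. These two differ in a single spot, (hydrogen in place of methoxy on an aromatic carbon), and the step of a number 9 percentage points lower from compound 2 to compound 1 (within the scatter) shows that removing that methoxy changed the read-out by no more than the assay itself wanders. Compound 3 `COc1cc(C(=O)/C=C/c2cc(-c3cc(OC)c(OC)c(OC)c3)n[nH]2)cc(OC)c1OC` is a different case: in this assay compound 3 gives -98%, the lowest of the three numbers, and its gap to each of the other two lies beyond the scatter. The difference between the core of compound 3 and the core of compound 2 is not broken down here.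

Compound 4 `COc1ccc(-c2cc(/C=C/C(=O)c3cc(OC)c(OC)c(OC)c3)[nH]n2)cc1OC` has not yet been measured. It is tied to compound 3 by hydrogen in place of methoxy on an aromatic carbon, the same kind of change that separates compound 2 from compound 1, although the surroundings are not identical: in compound 3 the carbon in question is also meta to a methoxy group (2 heavy atoms), which is not so in compound 2. Among the measured compounds shown here, the only guide to the size of this step is the earlier one, and because a number 9 percentage points lower from compound 2 to compound 1 (within the scatter) stayed within the scatter, a comparably small move is expected here, while the strong read-out of compound 3 leaves little room to fall further. Compound 4 is therefore expected to give -85%, with a likely range from -100% to -50%. The expected step is a number 13 percentage points higher from compound 3 to compound 4 (beyond the scatter).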

Compound 4, a percentage reported as activity, at one concentration (the size of the read-out at that concentration, not a potency): -99%
Estimate against measurement, compound 4: 14 percentage points above; measured number inside the range.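

In this assay, putting hydrogen in place of methoxy on an aromatic carbon gives a number 1 percentage points lower from compound 3 to compound 4 (within the scatter), so this swap has no visible effect on the core of compound 3 either. Set beside the earlier step, the same change behaves alike on the two cores tested, with no difference that can be told apart from ordinary assay noise: the same change on two cores in this assay, a number 9 percentage points lower (within the scatter) from compound 2 to compound 1 and a number 1 percentage points lower (within the scatter) from compound 3 to compound 4, 8 percentage points apart, within the scatter of two such steps This does not show that the swap would be just as quiet on a third core or at another place on these rings, and a step within the scatter means only that no effect could be seen at this single concentration, not that the methoxy could never matter.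

The compounds shown leave open what happens when this methoxy gives way to something other than hydrogen, such as a chlorine atom, a hydroxyl group or a longer ethoxy chain. Also open is which single feature separating the core of compound 2 from the core of compound 3 accounts for the large gap between those two compounds, including what part the amine of compound 2 plays.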